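A few compounds are considered here, and "the series" means these few. Any claim that something is new, unique, unknown or untested is made for them only; others in the source may bear on it.

The measured compounds:
compound 1, `CN(CCC#N)C[C@H]1CN(c2ccc(-n3cc(-c4ccccn4)cn3)c(F)c2)C(=O)O1`;
compound 2, `O=C1CSC(=O)N1C[C@H]1CN(c2ccc(-n3cc(-c4ccccn4)cn3)c(F)c2)C(=O)O1`, which in an ADME assay on HEK293-A cells (Homo sapiens) for cytotoxicity, read by MTT assay, with a stated time of 48 h (a higher number here means a weaker inhibitor, a lower number a stronger inhibitor), gives 283 ug/mL;
compound 3, `COC(=O)NC[C@H]1CN(c2ccc(-n3cc(-c4ccccn4)cn3)c(F)c2)C(=O)O1`, which in this assay gives 306 ug/mL.
In this assay compound 1 reaches only the assay limit of > 400 ug/mL.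

Compound 3 is one of two numbers in this assay, the other being compound 2, and a 1.1-fold higher number from compound 2 to compound 3 (0.03 log units; within the scatter). Against compound 1 the step is an at least 1.3-fold lower number from compound 1 to compound 3 (0.11 log units; that floor lies within the scatter), with compound 1 sitting at the limit of > 400 ug/mL in this assay, at which 1 of the 3 values shown sits. Compound 4, `O=C1O[C@@H](CNC(=O)C(F)(F)F)CN1c1ccc(-n2cc(-c3ccccn3)cn2)c(F)c1`, differs from compound 3 in one place: trifluoromethyl in place of methoxy on a carbonyl carbon. All three measured steps in this assay lie within the scatter, so no step beyond the scatter is expected for compound 4 either, and a number close to that of compound 3 is estimated. The expected step is a 1.0-fold lower number from compound 3 to compound 4 (0.01 log units; within the scatter), giving an estimate for compound 4 of 300 ug/mL, between 150 ug/mL and 400 ug/mL.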

Compound 4, half-maximal inhibitory concentration: > 400 ug/mL
Compound 4: no number, only a limit; the forecaster's own chance of this, stated with the estimate: 25%; middle value at least 1.3-fold (0.12 log units) from the limit.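

In this assay compound 4 gives only a limit, > 400 ug/mL, so a second side chain now stops there: the limit of > 400 ug/mL in this assay, at which 2 of the 4 values shown sit. Trifluoromethyl in place of methoxy on a carbonyl carbon gives an at least 1.3-fold higher number from compound 3 to compound 4 (0.11 log units; that floor lies within the scatter), and replacing 2,4-dioxo-1,3-thiazolidin-3-yl gives an at least 1.4-fold higher number from compound 2 to compound 4 (0.15 log units; that floor lies within the scatter), so neither change is shown to exceed the scatter. The step linking compound 1 and compound 4 cannot be read, as both values are limits.

As far as these compounds go, the true number for compound 4 remains open, and with it the real size of these steps. Also open, from the compounds shown here alone, is what a methyl or an amine on this carbonyl carbon would give in this assay.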